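Swapping methoxy for hydrogen on compound 1

The compounds below may be only part of what the source reports. "The series", "measured", "known", "first", "only" and "open" are said of these compounds alone.

Compound 1 (`COc1ccc(N=C2NC(=O)/C(=C\c3ccc(N(C)C)cc3)S2)cc1`) gives 2520 nM in a functional assay on NCI-H460 cells (Homo sapiens) for antiproliferative activity (on this read-out higher numbers stand for weaker inhibition and lower numbers for stronger inhibition), and stands level with the two other measured compounds. Compound 2 (`COc1ccc(/C=C2/S/C(=N/c3ccccc3C)NC2=O)cc1`) gives 1780 nM and compound 3 (`O=C1N/C(=N\c2ccc(Cl)cc2)S/C1=C/c1ccccc1O`) gives 1850 nM on the same read-out, both within the scatter of compound 1. Compound 4 (`CN(C)c1ccc(/C=C2/SC(=Nc3ccccc3)NC2=O)cc1`) differs from compound 1 by hydrogen in place of methoxy on an aromatic carbon, para to a large group, so that 4-methoxyphenyl becomes phenyl. Among the compounds with values here, no measured pair shows this change alone, so no step beyond the scatter is expected for it in this assay on present evidence. The expected step (a 1.3-fold lower number from compound 1 to compound 4 (0.10 log units; within the scatter)) is therefore small. For compound 4 the estimated value is 2000 nM with an expected range (900 nM to 4500 nM) around it.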

Compound 4, half-maximal inhibitory concentration: 500 nM
For compound 4 the middle estimate is 4.0-fold (0.60 log units) above the measured one; the measured number lies below the stated range.
By their numbers in this assay, from the lowest: compound 4; then compounds 2, 3 and 1 (each within the scatter of the next).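

In this assay, within the data shown here, hydrogen in place of methoxy gives a 5.0-fold lower number from compound 1 to compound 4 (0.70 log units; beyond the scatter), the only step here that lies beyond the scatter. Among these compounds, this shows that the aromatic carbon para to a large group is not indifferent to its substituent, as the near-level values of the earlier compounds could not reveal. Nothing given explains the step.

Going by these compounds, it remains open whether methoxy is specifically unfavourable here or whether a hydroxyl, an amine or a fluorine would give a similar number. On these data alone, whether the step carries over to other substitution on the rest of the molecule also remains open.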